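This account rests on a few compounds, and the source may have more. Where it says the series, first, only, none or still open, it means among the compounds named here.

Measured in a physicochemical assay for solubility; on this read-out lower numbers stand for lower solubility and higher numbers for higher solubility:
Compound 1 `O=C(O)c1ccc(C(=O)/C(=C\c2ccc(Cl)c([N+](=O)[O-])c2)SCc2ccc(Cl)cc2)cc1`: < 1000 ug/mL
Compound 2 `O=C(O)c1ccc(C(=O)/C(=C\c2ccc(F)c([N+](=O)[O-])c2)S(=O)(=O)Cc2ccc(Br)cc2)cc1`: < 1000 ug/mL
Compound 3 `O=C(O)c1ccc(C(=O)/C(=C\c2ccc(Cl)c([N+](=O)[O-])c2)SCc2ccccc2F)cc1`: < 1000 ug/mL

None of these entries is a number, and the set stands at the limit of < 1000 ug/mL in this assay, at which 3 of the 3 values shown sit. Compound 2 has only a limit, < 1000 ug/mL. Compound 4 `O=C(O)c1ccc(C(=O)/C(=C\c2ccc(F)c([N+](=O)[O-])c2)SCc2ccc(F)cc2)cc1` carries (4-fluorobenzyl)sulfanyl in place of (4-bromobenzyl)sulfonyl on a double-bonded chain carbon bound to a carbonyl carbon and a double-bonded chain carbon. Going by the values given here, the one measured step, a step that the two limits leave unreadable from compound 1 to compound 3, offers no size to carry over, so neither a size nor a direction can be drawn from it for this assay. The expected step, an estimate only, is a step that the limit leaves unreadable from compound 2 to compound 4. For compound 4 the estimated solubility is 300 ug/mL, with an expected range from 50 ug/mL to 1000 ug/mL.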

Compound 4, solubility: < 1000 ug/mL
Compound 4: only a limit was reported; the forecaster's own chance of this, stated with the estimate: 85%; the middle value is on the limit's open side.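

Going by these compounds alone, compound 2 and compound 4 each carry only a limit in this assay, so no step between them can be read. On these data alone, whether (4-fluorobenzyl)sulfanyl in place of (4-bromobenzyl)sulfonyl shifts the read-out at all, and in which direction, stays open.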